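Compound 4: swapping the aryl group on compound 1

The compounds below may be only part of what the source reports. "The series", "measured", "known", "first", "only" and "open" are said of these compounds alone.

Values in an ADME assay on Vero 76 cells (Chlorocebus sabaeus) for cytotoxicity, read by MTT assay, with a stated time of 96 h (a lower number here means that less compound is tolerated, a higher number that more compound is tolerated), are as follows:
compound 1 `NS(=O)(=O)c1ccc(N2N=C(c3ccc(OCc4ccccc4)cc3)CC2c2ccc(F)cc2)cc1` gives 90000 nM
compound 2 `NS(=O)(=O)c1ccc(N2N=C(c3ccc(Oc4ccccc4)cc3)CC2c2ccccc2)cc1` gives 85000 nM
compound 3 `NS(=O)(=O)c1ccc(N2N=C(c3ccc(Oc4ccccc4)cc3)CC2c2ccc(F)cc2)cc1` gives 25000 nM

Compound 1 sits at the upper end of this small set, within the scatter of compound 2, so the two are best read as level. Compound 4 `NS(=O)(=O)c1ccc(N2N=C(c3ccc(OCc4ccccc4)cc3)CC2c2cccc(Cl)c2)cc1` keeps the rest of compound 1 but carries 3-chlorophenyl in place of 4-fluorophenyl on a saturated ring carbon. Two measured steps offer some guidance. The closer one (a 3.4-fold lower number from compound 2 to compound 3 (0.53 log units; beyond the scatter)) is fluoro in place of hydrogen on an aromatic carbon, and it shows that a small swap can shift the number modestly. The other (a 3.6-fold lower number from compound 1 to compound 3 (0.56 log units; beyond the scatter)) is phenyl in place of benzyl on an oxygen on an aromatic ring, a different place in the molecule. Among the measured compounds shown here, no measured compound carries chlorine, so this evidence is thin. In this assay a small fall is expected, probably not beyond the scatter, and the estimated step is (a 1.5-fold lower number from compound 1 to compound 4 (0.18 log units; within the scatter)) in size. For compound 4 the estimated value is 60000 nM with an expected range from 25000 nM to 110000 nM as its limits.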

Compound 4, half-maximal cytotoxic concentration: 85000 nM
Compound 4: the middle estimate sits 1.4-fold (0.15 log units) below what was measured; the measured number falls inside the stated range.
By their numbers in this assay, from the lowest: compound 3; then compounds 2, 4 and 1 (each within the scatter of the next).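

In this assay, 3-chlorophenyl in place of 4-fluorophenyl on the saturated ring carbon gives a 1.1-fold lower number from compound 1 to compound 4 (0.02 log units; within the scatter), so compound 1 and compound 4 read as level even though both the halogen and its ring position differ. The earlier compounds shown here showed only a swap of hydrogen for fluoro at this ring, on a phenyl-on-oxygen background, and that gave a 3.4-fold lower number from compound 2 to compound 3 (0.53 log units; beyond the scatter), so a change to this aryl group does not always move the number beyond the scatter. Nothing measured here offers a reason for either outcome.

The compounds shown leave open how 3-chlorophenyl behaves when phenyl takes the place of benzyl on the oxygen. They also leave open whether an amine or a carboxylic acid on this aryl ring would read the same.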